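Sulfonamide glycinamide series: heteroaryl swap on the sulfonamide nitrogen

This account rests on a few compounds, and the source may have more. Where it says the series, first, only, none or still open, it means among the compounds named here.

Measured so far:
Compound 1 `CCc1ccccc1N(CC(=O)NCc1ccc(Br)cc1)S(=O)(=O)c1ccc(C)cc1`: 22.9 nM
Compound 2 `Cc1ccc(S(=O)(=O)N(CC(=O)NCc2ccc(Cl)cc2)c2cccnc2C)cc1`: 676 nM

Both were run in a functional assay on CHO-K1 cells for antagonist activity at prostaglandin E2 receptor EP1 subtype (Homo sapiens), read by FLIPR and calcium flux; on this read-out lower numbers stand for stronger inhibition and higher numbers for weaker inhibition. Of the two numbers, compound 2 gives the higher one; compound 1 gives a lower number, and the gap between the two is beyond the usual scatter. For the measured compounds named here, no pair of measured compounds differs in one place only, so no single step is on record.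

Compound 3 `Cc1ccc(S(=O)(=O)N(CC(=O)NCc2ccc(Cl)cc2)c2ccnn2C)cc1` is not yet measured. It differs from compound 2 in one place: 1-methyl-1H-pyrazol-5-yl in place of 2-methylpyridin-3-yl on a sulfonamide nitrogen. Nothing in the measured pair speaks to this change, so the expected step from compound 2 to compound 3 in this assay is about none beyond the scatter, with a wide margin either way; the estimated step is a 1.2-fold higher number from compound 2 to compound 3 (0.07 log units; within the scatter). Compound 3 is therefore estimated at 800 nM, with a range from 200 nM to 3200 nM.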

Compound 3, inhibition constant: 589 nM
Estimate against measurement, compound 3: 1.4-fold (0.13 log units) above; the measured number falls inside the stated range.
By their numbers in this assay, from the lowest: compound 1; then compounds 3 and 2 (each within the scatter of the next).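

In this assay, placing 1-methyl-1H-pyrazol-5-yl on the sulfonamide nitrogen instead of 2-methylpyridin-3-yl gives a 1.1-fold lower number from compound 2 to compound 3 (0.06 log units; within the scatter), so the two groups cannot be told apart here. For the compounds shown here, this is the first single-place step on record for the series, and it shows that a five-membered aromatic ring with 2 hetero atoms and a six-membered aromatic ring with 1 hetero atom read alike at this position. No measurement on hand bears on why these two groups read alike.

Compound 1 differs from compound 2 and compound 3 in more than one place, so its gap to them cannot be assigned to any single group. From the compounds shown here alone, whether an unsubstituted phenyl or a pyridin-3-yl without the methyl would read differently on the sulfonamide nitrogen stays open.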